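Adding a Second Methoxy Group to Compound 3

A few compounds are considered here, and "the series" means these few. Any claim that something is new, unique, unknown or untested is made for them only; others in the source may bear on it.

Measured so far in a functional assay for inhibition, with a stated time of 5 min, tested at 1 mM; on this read-out lower numbers stand for less inhibition and higher numbers for more inhibition at the one concentration tested (going by the name of the read-out):
compound 1 `COc1ccc2[nH]cc(C(=O)/C(C#N)=C/C=C(\Cl)c3ccc(Br)cc3)c2c1` gives 54.5%;
compound 2 `N#C/C(=C\C=C(/Cl)c1ccc(Br)cc1)C(=O)c1c[nH]c2ccccc12` gives 65.5%;
compound 3 `COc1ccc(/C(Cl)=C/C=C(\C#N)C(=O)c2c[nH]c3ccccc23)cc1` gives 61.3%.

The unmeasured compound 4 `COc1ccc(/C(Cl)=C/C=C(\C#N)C(=O)c2c[nH]c3ccccc23)cc1OC` arises from compound 3 through (methoxy in place of hydrogen on an aromatic carbon). The same kind of change has been made once before: compound 1 comes from compound 2 through (methoxy in place of hydrogen on an aromatic carbon), and the step was a number 11 percentage points lower from compound 2 to compound 1 (beyond the scatter). The two cores differ by methoxy in place of bromo on an aromatic carbon, and the places are not the same: in compound 1 the new methoxy sits on a ring that is part of a fused system, meta and para to a fused ring, while in compound 4 it sits ortho to a methoxy group and meta to a large group. A drop of similar size is expected, because the earlier change gave a number 11 percentage points lower from compound 2 to compound 1 (beyond the scatter). The expected step is a number 9.3 percentage points lower from compound 3 to compound 4 (within the scatter). Compound 4 is estimated at 52%, between 40% and 64%.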

Compound 4, a percentage reported as inhibition, at one concentration (the size of the read-out at that concentration, not a potency): 63.6%
Compound 4: the middle estimate sits 11.6 percentage points below what was measured; the measured number falls inside the stated range.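

In this assay, the added methoxy group gives a number 2.3 percentage points higher from compound 3 to compound 4 (within the scatter), so on this core the change has no clear effect on the read-out. Set side by side, the two results for this change cannot be told apart: the same change on two cores in this assay, a number 11 percentage points lower (beyond the scatter) from compound 2 to compound 1 and a number 2.3 percentage points higher (within the scatter) from compound 3 to compound 4, 13.3 percentage points apart, within the scatter of two such steps This does not show that the change behaves alike on both cores, since there are only two pairs, the new methoxy group sits in different places, and the scatter is wide compared with the steps.

On these data alone, it remains open how a hydroxyl group, an ethoxy group or an amine would fare at the place ortho to a methoxy group. As far as these compounds go, each number also comes from a single concentration, so potency itself remains open.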